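This account rests on a few compounds, and the source may have more. Where it says the series, first, only, none or still open, it means among the compounds named here.

Measured compounds in this series:

- compound 1, `CCCSc1nc(C(CC)c2c(F)cccc2Cl)c(C)c(=O)[nH]1`
- compound 2, `CCCCSc1nc(C(CC)c2c(F)cccc2Cl)c(C)c(=O)[nH]1`
- compound 3, `CCCSc1nc(C(CC)c2c(F)cccc2F)c(C)c(=O)[nH]1`

In an ADME assay on MT4 cells (Homo sapiens) for activation, read by MTT assay (a lower number here means that less compound is tolerated, a higher number that more compound is tolerated), compound 1 gives > 3000 nM, which is a limit of the assay and not a number. In this assay compound 2 gives > 3000 nM, again a limit. In this assay compound 3 gives > 3000 nM, also a limit. The change methyl in place of hydrogen on a saturated chain carbon, three bonds along the chain from a sulfur gives a step that the two limits leave unreadable from compound 1 to compound 2. The two cores differ by fluoro in place of chloro on an aromatic carbon, with a step that the two limits leave unreadable from compound 1 to compound 3. All three values sit at the same point, (the limit of > 3000 nM in this assay, at which 3 of the 3 values shown sit).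

Compound 4, `CCC(C)Sc1nc(C(CC)c2c(F)cccc2F)c(C)c(=O)[nH]1`, carries the change (methyl in place of hydrogen on a saturated chain carbon bound to a saturated chain carbon and a sulfur). This is the same kind of change as in compound 2, but the place differs: there the methyl enters on a saturated chain carbon three bonds along the chain from a sulfur, here on a saturated chain carbon bound to a saturated chain carbon and a sulfur. In this assay the step from the first pair is unreadable, so the expected step that the limit leaves unreadable from compound 3 to compound 4 rests only on compound 3 standing at > 3000 nM and is an estimate. Compound 4 is expected to give 5000 nM, within 3000 nM to 20000 nM, most likely again reported as a limit.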

Compound 4, half-maximal cytotoxic concentration: > 3000 nM
Compound 4 ended at the assay's limit; the forecaster's own chance of this, stated with the estimate: 85%; the middle value is on the limit's open side.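

In this assay no step can be read between compound 3 and compound 4, because both values are limits and not numbers: the limit of > 3000 nM in this assay, at which 4 of the 4 values shown sit.

The compounds shown leave open where any of their true cytotoxic concentrations lie, and so whether any of these changes shifts the read-out.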